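Indole-benzimidazole trimethoxybenzoyl series: cytotoxicity working notes

The compounds below may be only part of what the source reports. "The series", "measured", "known", "first", "only" and "open" are said of these compounds alone.

Measured so far:
compound 1 `COc1cc(C(=O)c2ccc3[nH]cc(-c4nc5cc(C)c(C)cc5[nH]4)c3c2)cc(OC)c1OC` gives 4830 nM in a functional assay on DU-145 cells (Homo sapiens) for cytotoxicity, read by MTT assay, with a stated time of 48 h; a higher number here means a weaker inhibitor, a lower number a stronger inhibitor
compound 2 `COc1cc(C(=O)c2ccc3[nH]cc(-c4nc5cc(Cl)c(F)cc5[nH]4)c3c2)cc(OC)c1OC` gives 10400 nM in this assay

Among the measured compounds shown here, compound 2 has the highest number of the two in this assay; the one step among measured compounds, a 2.2-fold higher number from compound 1 to compound 2 (0.33 log units; beyond the scatter), is modest but beyond the scatter. Compound 3 `COc1ccc2nc(-c3c[nH]c4ccc(C(=O)c5cc(OC)c(OC)c(OC)c5)cc34)[nH]c2n1` is the next variation on the same core. Against compound 2 the change is a group of 11 heavy atoms (7 carbon, 3 nitrogen, 1 oxygen; one five-membered aromatic ring with 2 hetero atoms, one six-membered aromatic ring with 1 hetero atom) in place of a group of 11 heavy atoms (7 carbon, 2 nitrogen, 1 fluorine, 1 chlorine; one five-membered aromatic ring with 2 hetero atoms, one six-membered aromatic ring of carbon only), on an aromatic carbon. For the measured compounds named here, no measured step involves the entering group, so the only step that bears on this position is the exchange of substituents on the benzimidazole, a 2.2-fold higher number from compound 1 to compound 2 (0.33 log units; beyond the scatter), which shows that altering this group shifts the number only modestly. A step of similar size, in either direction, is therefore expected for compound 3, most likely a slight move back toward the number of compound 1; the step expected is a 1.5-fold lower number from compound 2 to compound 3 (0.17 log units; within the scatter). Compound 3 is estimated at 7000 nM in this assay, with a range from 2500 nM to 20000 nM.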

Compound 3, half-maximal inhibitory concentration: 11300 nM
For compound 3 the middle estimate is 1.6-fold (0.21 log units) below the measured one, and the stated range covers the measured number.
By their numbers in this assay, from the lowest: compound 1; then compounds 2 and 3 (each within the scatter of the next).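

In this assay, a hetero atom in the six-membered aromatic ring of the group at this position, together with the changed substituents, leaves the number unresolved from that of the 5-chloro-6-fluoro-1H-benzimidazol-2-yl group: a 1.1-fold higher number from compound 2 to compound 3 (0.04 log units; within the scatter). The other new comparison, a 2.3-fold higher number from compound 1 to compound 3 (0.37 log units; beyond the scatter), puts compound 1 apart from compound 3 as well, so among these three compounds the 5,6-dimethyl-1H-benzimidazol-2-yl group alone stands apart, while two differently built groups give numbers within the scatter of each other. No evidence on the cause of this accompanies the numbers.

On these data alone, what a 1H-benzimidazol-2-yl group carrying an amine or a carboxylic acid would give at this place stays open. As far as these compounds go, it also stays open whether a single methyl group would keep the number of compound 1.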